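The source may hold more compounds than are shown below. What is called first, only, known or untested is meant among the compounds shown, and "the series" means these compounds.

Going by the values given here, compound 2 `N#CC1=C(N)N(c2ccc(S(N)(=O)=O)cc2)C2=C(CCCC2)C1c1ccc(O)cc1` stands highest of the two numbers so far in a functional assay on Ehrlich cells (Mus musculus) for cytotoxicity, read by trypan blue exclusion, with a stated time of 2 h, tested at 25 ug/mL (on this read-out lower numbers stand for a weaker effect and higher numbers for a stronger effect at the one concentration tested), where compound 2 gives 42%. Among the compounds with values here, its only measured neighbour is compound 1 `Cc1ccc(C2C(C#N)=C(N)N(c3ccc(S(N)(=O)=O)cc3)C3=C2CCCC3)cc1`, which in this assay gives 30%; the step of a number 12 percentage points higher from compound 1 to compound 2 (beyond the scatter) is the single change with a known outcome.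

Compound 3 `N#CC1=C(N)N(c2ccc(S(N)(=O)=O)cc2)C2=C(CCCC2)C1/C=C/c1ccccc1` differs from compound 2 by 2-phenylethenyl in place of 4-hydroxyphenyl on a saturated ring carbon. Within the data shown here, no measured step covers exactly this exchange. Among the measured compounds shown here, the one step that bears on it, the move from compound 1 to compound 2, concerns the hydroxy that now leaves, and it was modest. For the measured compounds named here, compound 3 loses that hydroxy, and in that respect it resembles compound 1, whose read-out of 30% is the lower of the two; the 2-phenylethenyl group that enters has no measured counterpart here, so its own contribution is unknown and widens the uncertainty. On balance a step of a number 10 percentage points lower from compound 2 to compound 3 (within the scatter) is expected, roughly undoing the earlier gain. Compound 3 is therefore estimated at 32%, with a range from 15% to 55%.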

Compound 3, a percentage reported as activity, at one concentration (the size of the read-out at that concentration, not a potency): 70%
Compound 3: the middle estimate sits 38 percentage points below what was measured, and the stated range ends below it.
By their numbers in this assay, from the lowest: compound 1; then compound 2; then compound 3.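

The exchange of 4-hydroxyphenyl for 2-phenylethenyl on the saturated ring carbon gives a number 28 percentage points higher from compound 2 to compound 3 (beyond the scatter) in this assay and the exchange of 4-methylphenyl for the same group gives a number 40 percentage points higher from compound 1 to compound 3 (beyond the scatter) as its outcome. The group held directly on this carbon therefore moves the read-out further than the earlier change on the aromatic ring did, and this position is not limited to groups in which the aromatic ring sits directly on the carbon. Compound 1 and compound 3 both lack the hydroxy, yet compound 3 has the highest number of the three, so a hydroxy is not needed for a strong effect here, and nothing measured in this account explains why the 2-phenylethenyl group has this outcome.

The compounds shown do not separate the double bond from the aromatic ring it carries, and a 2-phenylethyl group, with a saturated chain in place of the double bond, or a plain methyl group on this carbon would begin to tell these apart. From the compounds shown here alone, it also remains open whether a hydroxy on the phenyl ring of the 2-phenylethenyl group would add to the read-out, as the hydroxy did from compound 1 to compound 2.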